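Working notes: 2-methoxyphenyl in place of thiophen-2-yl

The compounds below may be only part of what the source reports. "The series", "measured", "known", "first", "only" and "open" are said of these compounds alone.

compound 1 `COc1ccc(/C=C/C(=O)/C=C/c2ccc(OCc3cn(CCCCCOc4cc(=O)oc5ccccc45)nn3)c(OC)c2)cc1OC` gives "not active" (no number reported)
compound 2 `COc1cc(/C=C/C(=O)/C=C/c2cccs2)ccc1OCc1cn(CCOc2cc(=O)oc3ccccc23)nn1` gives 12%

In a functional assay on PC-3 cells (Homo sapiens) for inhibition, read by sulforhodamine B assay, with a stated time of 48 h, tested at 50 uM (on this read-out higher numbers stand for more inhibition of growth at the one concentration tested and lower numbers for less inhibition of growth), compound 2 (12%) holds the only number shown so far, and it sits low on that scale. Compound 1 ("not active" (no number reported)) has no number reported.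

Next in line is compound 3 `COc1ccccc1/C=C/C(=O)/C=C/c1ccc(OCc2cn(CCOc3cc(=O)oc4ccccc34)nn2)c(OC)c1`, still to be measured in this assay. It carries 2-methoxyphenyl in place of thiophen-2-yl on a double-bonded chain carbon bound to a double-bonded chain carbon. Among the measured compounds shown here, no measured step bears on this change, so the expectation rests on compound 2 (12%) alone. The expected step (a number 2 percentage points higher from compound 2 to compound 3 (within the scatter)) stays within the usual scatter, with no firm direction. A result without a number also remains possible. For compound 3 the estimated value is (14%), with an expected range from 3% to 32% (both ends estimated).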

Compound 3, percent growth inhibition at one concentration: 11%
Compound 3: the middle estimate sits 3 percentage points above what was measured; low and high end bracket the measured number.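

In this assay, among the compounds shown here, this is the first measured step at this position (a number 1 percentage points lower from compound 2 to compound 3 (within the scatter)): 2-methoxyphenyl in place of thiophen-2-yl on a double-bonded chain carbon bound to a double-bonded chain carbon does not separate the two compounds. Going from a five-membered aromatic ring with 5 heavy atoms to a six-membered aromatic ring of carbon only with 8 heavy atoms therefore leaves the read-out within the scatter at the one concentration tested. No measurement shown explains why the two compounds read alike.

On these data alone, whether a phenyl ring carrying a carboxylic acid or a dimethylamino group at this place would move the growth inhibition remains open. For the compounds shown here, compound 1 has no reported number, so no step involving it can be read.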